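A few compounds are considered here, and "the series" means these few. Any claim that something is new, unique, unknown or untested is made for them only; others in the source may bear on it.

Measured compounds:
compound 1, `CCCn1c(=O)c2c(nc(-n3cc(I)cn3)n2Cc2ccccc2)n(CCC)c1=O` — > 5800 nM
compound 2, `CCn1c(=O)c2nc(-c3cnn(Cc4ccccc4)c3)[nH]c2n(CC)c1=O` — 19 nM

In an in vitro assay on HEK293 cells for displacement of a labelled ligand from adenosine receptor A2b (Homo sapiens) (a lower number here means a stronger inhibitor, a higher number a weaker inhibitor), compound 1 returns only a limit, > 5800 nM; the value stands at the limit of > 5800 nM in this assay, at which 1 of the 2 values shown sits, so no number is known for it. Compound 2, of which nothing is said here beyond its own value, gives 19 nM in this assay. Among the compounds with values here, no step between the two is computed, and their structures differ in more than one place, so the two values are reported side by side without comparison.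

Compound 3, `CCCn1c(=O)c2c(nc(-n3cccn3)n2Cc2ccccc2)n(CCC)c1=O`, is not yet measured in this assay. It differs from compound 1 by hydrogen in place of iodo on an aromatic carbon. Since compound 1 sits at a limit, the starting point for the step is itself uncertain; the expectation is a step that the limit leaves unreadable from compound 1 to compound 3, in no clear direction beyond the scatter. Compound 3 is expected to give about 6000 nM, within 1500 nM to 30000 nM, with a fair chance that only a limit is reported again.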

Compound 3, inhibition constant: > 5800 nM
Compound 3 was reported as a limit; the forecaster's own chance of this, stated with the estimate: 60%; the middle value lies beyond the limit too.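

Compound 1 and compound 3 both stand at a limit in this assay, so no step between them can be read: the limit of > 5800 nM in this assay, at which 2 of the 3 values shown sit.

As far as these compounds go, whether hydrogen in place of iodo on the aromatic carbon changes the read-out at all remains open.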